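Changing the aryl group on an aromatic nitrogen

A few compounds are considered here, and "the series" means these few. Any claim that something is new, unique, unknown or untested is made for them only; others in the source may bear on it.

Compound 1 `CCOc1ccc(-n2nncc2CN2C(=O)C3(C(C#N)=C(N)Oc4c3c3nc5ccccc5nc3c3ccccc43)c3ccccc32)cc1` gives 25200 nM in a functional assay on A549 cells (Homo sapiens) for antiproliferative activity, read by MTT assay, with a stated time of 48 h; a lower number here means a stronger inhibitor, a higher number a weaker inhibitor. Compound 2 `Cc1ccc(-n2nncc2CN2C(=O)C3(C(C#N)=C(N)Oc4c3c3nc5ccccc5nc3c3ccccc43)c3ccccc32)cc1Cl` gives only a limit, > 50000 nM, in this assay. Compound 3 `CCc1ccccc1-n1nncc1CN1C(=O)C2(C(C#N)=C(N)Oc3c(N)cc4nc5ccccc5nc4c32)c2ccccc21` gives 24600 nM in this assay.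

Compound 3 holds the lowest of the two numbers, with compound 1 within the scatter of it. Compound 4 `CCOc1ccc(-n2nncc2CN2C(=O)C3(C(C#N)=C(N)Oc4c(N)cc5nc6ccccc6nc5c43)c3ccccc32)cc1` differs from compound 3 by 4-ethoxyphenyl in place of 2-ethylphenyl on an aromatic nitrogen. Going by the values given here, the one measured step that alters the group on that aromatic nitrogen is an at least 1.9-fold higher number from compound 1 to compound 2 (0.29 log units; that floor lies within the scatter). Compound 2 sits at the limit of > 50000 nM in this assay, at which 1 of the 3 values shown sits. Among the compounds with values here, no measured pair swaps 2-ethylphenyl for 4-ethoxyphenyl, but compound 1 carries the same 4-ethoxyphenyl as compound 4 and gives a number within the scatter of compound 3. The expected step, a 1.0-fold higher number from compound 3 to compound 4 (0.01 log units; within the scatter), is none beyond the scatter. Compound 4 is therefore estimated at 25000 nM, within 10000 nM to 60000 nM.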

Compound 4, half-maximal inhibitory concentration: > 50000 nM
Compound 4: no number, only a limit; the forecaster's own chance of this, stated with the estimate: 20%; middle value at least 2.0-fold (0.30 log units) from the limit.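

In this assay compound 4 gives only a limit, > 50000 nM. The swap of 2-ethylphenyl for 4-ethoxyphenyl reads as an at least 2.0-fold higher number from compound 3 to compound 4 (0.30 log units; that floor lies within the scatter), so this change at the aromatic nitrogen has only a floor, and that floor does not pass the scatter. The 4-ethoxyphenyl group gives a number with compound 1 but only a limit with compound 4, and the limit now holds more of the values: the limit of > 50000 nM in this assay, at which 2 of the 4 values shown sit.

Going by these compounds, how compound 2 and compound 4 truly rank remains open. So does whether an amine or a carboxylic acid on the phenyl ring, or a chain longer than ethoxy, would give a measurable number.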